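Replacing a Heptyl Chain with Phenyl

This account rests on a few compounds, and the source may have more. Where it says the series, first, only, none or still open, it means among the compounds named here.

In a physicochemical assay for lipophilicity, at pH 7.4 (on this read-out higher numbers stand for higher lipophilicity and lower numbers for lower lipophilicity), compound 1 (`CCCCCCCc1c(C)nc2ccccc2c1O`) gives 3.39 while compound 2 (`CCCCCCC/C=C/c1c(C)[nH]c2ccccc2c1=O`) gives 4.26 as the higher of the two numbers, a gap beyond the usual scatter. Compound 3 (`Cc1[nH]c2ccccc2c(=O)c1/C=C/c1ccccc1`) is still unmeasured. It differs from compound 2 by phenyl in place of heptyl on a double-bonded chain carbon bound to a double-bonded chain carbon. Among the compounds with values here, no measured pair shows this swap alone, so a fall in this assay beyond the scatter is only a rough expectation, with a number 1.06 log units lower from compound 2 to compound 3 (beyond the scatter) as the estimated step. Compound 3 is expected at 3.2 (estimated range 2.6 to 3.8).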

Compound 3, distribution coefficient: 4.4
Estimate against measurement, compound 3: 1.20 log units below; measured number outside the range, above it.
By their numbers in this assay, from the lowest: compound 1; then compounds 2 and 3 (each within the scatter of the next).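

In this assay phenyl in place of heptyl on a double-bonded chain carbon bound to a double-bonded chain carbon gives a number 0.14 log units higher from compound 2 to compound 3 (within the scatter) and so leaves the two groups indistinguishable at this position. An open chain and a six-membered aromatic ring of carbon only can therefore read alike here. Nothing measured explains this match. As far as these compounds go, how an amine, a carboxylic acid or a longer chain would read at this place stays open. So does whether the match between heptyl and phenyl would hold on another core.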